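This account rests on a few compounds, and the source may have more. Where it says the series, first, only, none or still open, it means among the compounds named here.

The measured compounds:

Compound 1, `O=c1cc(-c2ccccc2)oc2cccc(OCCCCN3CCC(O)CC3)c12` — in an assay on isolated protein (Cavia porcellus) with Sigma non-opioid intracellular receptor 1 (Homo sapiens) as the target, read by radioligand binding (on this read-out higher numbers stand for weaker inhibition and lower numbers for stronger inhibition), compound 1 gives 177 nM.
Compound 2, `O=c1cc(-c2ccccc2)oc2cccc(OCCCCCCCN3CCC(O)CC3)c12` — in this assay compound 2 gives 65 nM.
Compound 3, `CN(C)CCCCOc1ccc2oc(-c3ccccc3)cc(=O)c2c1` — in this assay compound 3 gives 400 nM.

Among these three, compound 3 stands at the highest number: the value of compound 1 is lower than that of compound 3, and the value of compound 2 is lower still, the gap to compound 2 being the wider one.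

Compound 4, `CN(C)CCCCCCCOc1ccc2oc(-c3ccccc3)cc(=O)c2c1`, has not yet been measured. It differs from compound 3 by a single change, (3-(dimethylamino)propyl in place of dimethylamino on a saturated chain carbon, four bonds along the chain from an oxygen on an aromatic ring), so the basic nitrogen is carried out to the end of a longer saturated chain while the rest of the molecule is untouched.

Among the measured compounds shown here, one measured step bears directly on this change: a 2.7-fold lower number from compound 1 to compound 2 (0.44 log units; beyond the scatter), where the same kind of chain lengthening was made on a core carrying a hydroxypiperidine instead of a dimethylamino group. That step was modest but beyond the scatter, and it ran toward a lower number. For the measured compounds named here, no measured pair shows the chain lengthening with the dimethylamino group itself, so the transfer to compound 4 rests on this single precedent.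

Compound 4 is therefore expected to show a lowering of similar size, a 2.7-fold lower number from compound 3 to compound 4 (0.43 log units; beyond the scatter), because a 2.7-fold lower number from compound 1 to compound 2 (0.44 log units; beyond the scatter) moved in that direction. The estimate for compound 4 in this assay is 150 nM, with a range from 60 nM to 400 nM.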

Compound 4, half-maximal inhibitory concentration: 188 nM
Compound 4: middle estimate off by 1.3-fold (0.10 log units), on the low side; the range from low to high includes it.
By their numbers in this assay, from the lowest: compound 2; then compounds 1 and 4 (each within the scatter of the next); then compound 3.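

In this assay, among the compounds shown here, putting 3-(dimethylamino)propyl in place of dimethylamino on a saturated chain carbon, four bonds along the chain from an oxygen on an aromatic ring, gives a 2.1-fold lower number from compound 3 to compound 4 (0.33 log units; beyond the scatter) and so provides the first measured pair for this lengthening with a dimethylamino chain end. Alongside a 2.7-fold lower number from compound 1 to compound 2 (0.44 log units; beyond the scatter), which has a 4-hydroxypiperidin-1-yl chain end, the change now lowers the number in both available pairs, each step modest, and neither pair goes against this direction. Nothing available explains the shift in either pair, and no measurement of a property of these compounds bears on it.

The compounds shown leave open whether the number keeps falling with a still longer chain, or how a chain of intermediate length behaves between the two lengths in each pair. They also leave open how a dimethylamino chain end compares with a 4-hydroxypiperidin-1-yl chain end on one and the same core, and what a morpholine or an unsubstituted piperidine would do at the end of either chain.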